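The source may hold more compounds than are shown below. What is called first, only, known or untested is meant among the compounds shown, and "the series" means these compounds.

Compounds measured in a functional assay on SK-MEL-5 cells (Homo sapiens) for inhibition; a lower number here means a stronger inhibitor of growth, a higher number a weaker inhibitor of growth:
Compound 1, `Cc1cc(S(=O)(=O)Nc2nc3ccsc3c(=O)n2Cc2ccccc2)c(S)cc1Cl`, gives 12500 nM.
Compound 2, `Cc1cc(S(=O)(=O)Nc2nc3cc(-c4ccccc4)sc3c(=O)n2Cc2ccccc2)c(S)cc1Cl`, gives only a limit, > 100000 nM.

Going by the values given here, the single measured step, an at least 8.0-fold higher number from compound 1 to compound 2 (0.90 log units; beyond the scatter), runs up to the boundary of what this assay reports, (the limit of > 100000 nM in this assay, at which 1 of the 2 values shown sits). Compound 2 thus stands at the weak end of the measured pair, its value known only as a limit and not as a number.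

Compound 3, `Cc1cc(S(=O)(=O)Nc2nc3cc(-c4ccc(Cl)cc4)sc3c(=O)n2Cc2ccccc2)c(S)cc1Cl`, differs from compound 2 by chloro in place of hydrogen on an aromatic carbon. Among the compounds with values here, no measured step concerns a chloro on that phenyl; the only step available, an at least 8.0-fold higher number from compound 1 to compound 2 (0.90 log units; beyond the scatter), concerns the phenyl itself and already placed compound 2 at the limit. From such a starting point the expected change for compound 3 is a step that the limit leaves unreadable from compound 2 to compound 3, that is, nothing beyond the scatter. Compound 3 is therefore estimated at 150000 nM, with a range of 40000 nM to 500000 nM, and will most probably again be reported only as a limit.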

Compound 3, concentration for 50% growth inhibition: > 100000 nM
Compound 3 ended at the assay's limit; the forecaster's own chance of this, stated with the estimate: 85%; the middle value does not contradict the limit.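

In this assay, 4-chlorophenyl in place of hydrogen on the aromatic carbon gives an at least 8.0-fold higher number from compound 1 to compound 3 (0.90 log units; beyond the scatter), so this position has now twice taken an aryl group with the same outcome. Chloro on that phenyl does not return compound 3 to a readable value. The step from compound 2 to compound 3 cannot be read, because both compounds rest at a limit and not at a number: the limit of > 100000 nM in this assay, at which 2 of the 3 values shown sit.

Any order between compound 2 and compound 3 stays unknown, as does how far each lies past the limit. Also open, going by these compounds, is whether a methyl group at this position, or an amine or a carboxylic acid on the phenyl, would give a readable value.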